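A few compounds are considered here, and "the series" means these few. Any claim that something is new, unique, unknown or untested is made for them only; others in the source may bear on it.

Measured in an ADME assay on MT4 cells (Homo sapiens) for cytotoxicity, read by MTT assay; on this read-out lower numbers stand for higher toxicity in this test and higher numbers for lower toxicity in this test:
Compound 1 `O=C(CSc1nccn1-c1ccc(Cl)cc1)Nc1ccccc1[N+](=O)[O-]`: > 321000 nM, which is a limit of the test and not a number.
Compound 2 `Cc1ccc(-n2ccnc2SCC(=O)Nc2ccccc2[N+](=O)[O-])cc1`: 131000 nM.
Compound 3 `O=C(CSc1nccn1-c1cccc2ccccc12)Nc1ccccc1Cl`: 35200 nM.

Compound 1 sits at the limit given by the limit of > 321000 nM in this assay, at which 1 of the 3 values shown sits. From compound 1 to compound 2 the change is methyl in place of chloro on an aromatic carbon, and it brings an at least 2.4-fold lower number from compound 1 to compound 2 (0.38 log units; beyond the scatter). Compound 3 and compound 1 differ in more than one place; the difference between the two cores is not broken down here. Compound 4 `Cc1ccccc1NC(=O)CSc1nccn1-c1cccc2ccccc12`, still to be measured in this assay, differs from compound 3 by methyl in place of chloro on an aromatic carbon. This is the same kind of change as from compound 1 to compound 2, but there the place is para to a large group and here it is ortho to a large group, so the earlier step is only a rough guide. Resting on that earlier step and on the value of compound 3 35200 nM, compound 4 is expected to show a 1.4-fold lower number from compound 3 to compound 4 (0.15 log units; within the scatter). The estimate for compound 4 is 25000 nM, expected to lie between 10000 nM and 60000 nM.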

Compound 4, half-maximal cytotoxic concentration: 34600 nM
The estimate for compound 4 lay 1.4-fold (0.14 log units) below the measured number; measured number inside the range.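

In this assay, methyl in place of chloro on an aromatic carbon, here 2-chlorophenyl to 2-methylphenyl, gives a 1.0-fold lower number from compound 3 to compound 4 (0.01 log units; within the scatter), which lies within the scatter. Set beside the earlier case, the change on the two cores reads: the same change on two cores in this assay, an at least 2.4-fold lower number (0.38 log units; beyond the scatter) from compound 1 to compound 2 and a 1.0-fold lower number (0.01 log units; within the scatter) from compound 3 to compound 4; the limit leaves it open whether they differ. Compound 1 carries a limit and not a number, so the size of the first step stays unfixed and the pair does not show whether the change carries from one core to the other: the limit of > 321000 nM in this assay, at which 1 of the 4 values shown sits.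

The compounds shown compare only chloro and methyl at this place on each core. From the compounds shown here alone, how a fluoro, a methoxy or an amine there would read in this assay remains open, as does whether the core of compound 3 would give the same result with any of them.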